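The compounds below may be only part of what the source reports. "The series", "measured", "known", "first", "only" and "open" are said of these compounds alone.

Measured compounds in an assay on isolated protein for inhibition of N-lysine methyltransferase SMYD2 (Homo sapiens), read by filter binding, with a stated time of 1 h; on this read-out lower numbers stand for stronger inhibition and higher numbers for weaker inhibition:
Compound 1, `CN1C(=O)C(CCNc2ccccc2)COC12C=CC(=O)C=C2`, gives a value of > 20000 nM, which is a limit of this assay and not a number.
Compound 2, `CN1C(=O)C(CCNc2cccnc2)COC12C=CC(=O)C=C2`, gives a value of > 20000 nM, again a limit of this assay rather than a number.
Compound 3, `CN1C(=O)C(CCNc2ccc(F)cc2)COC12C=CC(=O)C=C2`, gives 11600 nM.

Going by the values given here, compound 3 thus holds the only number so far; the other two results sit at a limit, as stated in the limit of > 20000 nM in this assay, at which 2 of the 3 values shown sit. The steps to it are an at least 1.7-fold lower number from compound 1 to compound 3 (0.23 log units; that floor lies within the scatter) and an at least 1.7-fold lower number from compound 2 to compound 3 (0.23 log units; that floor lies within the scatter), and each is only a floor, lying within the scatter. The step between compound 1 and compound 2 is a step that the two limits leave unreadable from compound 1 to compound 2.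

Compound 4, `CN1C(=O)C(CCNc2ccc(Cl)c(Cl)c2)COC12C=CC(=O)C=C2`, is not yet measured. The change from compound 3 is 3,4-dichlorophenyl in place of 4-fluorophenyl on an amine nitrogen. Among the compounds with values here, no measured step swaps one halogenated phenyl for another, so only the floor of an at least 1.7-fold lower number from compound 1 to compound 3 (0.23 log units; that floor lies within the scatter) bears on it, and that floor is too small to set a direction beyond the scatter. The expected step in this assay is therefore a 1.7-fold lower number from compound 3 to compound 4 (0.22 log units; within the scatter), with the real chance that compound 4 again reports only a limit. Compound 4 is estimated at 7000 nM, within 1500 nM to 25000 nM.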

Compound 4, half-maximal inhibitory concentration: 3820 nM
Compound 4: the middle estimate sits 1.8-fold (0.26 log units) above what was measured, and the stated range covers the measured number.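

Going by these compounds alone, replacing 4-fluorophenyl with 3,4-dichlorophenyl on the amine nitrogen gives a 3.0-fold lower number from compound 3 to compound 4 (0.48 log units; beyond the scatter), the first step at this position in this assay that joins two real numbers and clears the scatter. Measured against the compounds without a halogen, the same group gives an at least 5.2-fold lower number from compound 1 to compound 4 (0.71 log units; beyond the scatter) and an at least 5.2-fold lower number from compound 2 to compound 4 (0.71 log units; beyond the scatter); both are only floors, but unlike the earlier floors they lie beyond the scatter. The group on this nitrogen can therefore move the read-out towards stronger inhibition, while compound 1 and compound 2 still report a limit rather than a number: the limit of > 20000 nM in this assay, at which 2 of the 4 values shown sit.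

The step from compound 3 to compound 4 removes a fluorine and adds two chlorines in one change, so these compounds cannot show whether a phenyl with a single chlorine would give the same result or whether both chlorines are needed. Also open, going by these compounds, is how a trifluoromethyl or methoxy group on the phenyl ring, or a longer chain on the amine nitrogen, would compare with 3,4-dichlorophenyl.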